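Branching the Alkylamino Chain in a Thiadiazole Amide Series

The source may report more compounds than this note shows. Statements on the series, on what has been measured and on what is new or still open speak of the compounds shown alone.

Compound 1: `CCCCNc1nnc(SCC(=O)N(Cc2cccc([N+](=O)[O-])c2)c2ccc(F)cc2)s1` gives 1180 nM in an assay on isolated protein for inhibition of Amine oxidase [flavin-containing] A (Homo sapiens), read by fluorescence and Amplex Red, with a stated time of 30 min; a lower number here means a stronger inhibitor, a higher number a weaker inhibitor.
Compound 2: `CCCNc1nnc(SCC(=O)N(Cc2cccc([N+](=O)[O-])c2)c2ccc(F)cc2)s1` gives 241 nM in this assay.

For the measured compounds named here, compound 2 stands as the lower of the two numbers measured so far in this assay, and the only step that connects it to another compound is a 4.9-fold lower number from compound 1 to compound 2 (0.69 log units; beyond the scatter), where hydrogen replaced methyl on the chain. Going by the values given here, that is the single piece of evidence about what the chain on the aromatic nitrogen contributes.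

Compound 3, `CC(C)CNc1nnc(SCC(=O)N(Cc2cccc([N+](=O)[O-])c2)c2ccc(F)cc2)s1`, has not yet been measured in this assay. It differs from compound 2 by methyl in place of hydrogen on a saturated chain carbon bound to two saturated chain carbons, so the propylamino group becomes isobutylamino. Adding a methyl runs in the opposite direction to the one measured step, which removed one, so the expectation is a higher number for compound 3 than for compound 2, though a smaller rise than the step between compound 1 and compound 2; the new methyl sits on a different chain carbon, and no measured compound carries a methyl there. The estimated step is a 2.5-fold higher number from compound 2 to compound 3 (0.40 log units; beyond the scatter). For compound 3 the expected value in this assay is 600 nM, within a range from 250 nM to 1500 nM.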

Compound 3, half-maximal inhibitory concentration: 1790 nM
Estimate against measurement, compound 3: 3.0-fold (0.47 log units) below; the whole stated range lies below it.
By their numbers in this assay, from the lowest: compound 2; then compounds 1 and 3 (each within the scatter of the next).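

A methyl on the saturated chain carbon bound to two saturated chain carbons, which turns propylamino into isobutylamino, gives a 7.4-fold higher number from compound 2 to compound 3 (0.87 log units; beyond the scatter) in this assay, so this position also responds to a branch and not only to the straight extension from propylamino to the butylamino chain of compound 1. The straight chain and the branched chain cannot be told apart here, with a 1.5-fold higher number from compound 1 to compound 3 (0.18 log units; within the scatter), so among these three compounds both larger chains stand apart from propylamino, whichever of the two shapes the added methyl produces. Nothing measured here accounts for this sensitivity to one added methyl.

An ethylamino group or a plain amine at this place would show whether the number keeps falling as the chain shortens or whether propylamino is a low point. A cyclopropylmethylamino group or a sec-butylamino chain would show whether a ring, or a branch on a different chain carbon, is met with the same rise.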